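Pentyl-substituted aminobenzimidazoles: substitution at the fused ring

This account rests on a few compounds, and the source may have more. Where it says the series, first, only, none or still open, it means among the compounds named here.

Compound 3 `CCCCCn1c(N)nc2c(N(C)C)cccc21` carries a dimethylamino group on the fused benzene ring and in an assay on HEK293 cells for agonist activity at Toll-like receptor 8 (Homo sapiens), read by reporter gene assay (on this read-out higher numbers stand for an effect only at larger amounts of compound and lower numbers for an effect already at smaller amounts), compound 3 gives 7120 nM. Within the series it holds the highest number of the two reported: the parent, compound 1 `CCCCCn1c(N)nc2ccccc21`, gives 3230 nM in this assay, and the chloro analogue, compound 2 `CCCCCn1c(N)nc2c(Cl)cccc21`, is recorded in this assay as "not active" (no number reported) without a number. For the measured compounds named here, the step of a 2.2-fold higher number from compound 1 to compound 3 (0.34 log units; beyond the scatter) is the only quantified step that bears on a change at this position, and it runs toward weaker activity; compound 2 points the same way without a value.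

Compound 4 `CCCCCn1c(N)nc2c([N+](=O)[O-])cccc21` differs from compound 3 by nitro in place of dimethylamino on an aromatic carbon. Both earlier substituents at this carbon gave a higher number or no activity, so a further modest rise, or a result without a number, is expected here. On this basis compound 4 is estimated at 12000 nM in this assay, with a range of 4000 nM to 40000 nM, corresponding to an expected step of a 1.7-fold higher number from compound 3 to compound 4 (0.23 log units; within the scatter).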

Compound 4, half-maximal effective concentration: "not active" (no number reported)
Compound 4 has no reported number here; the estimate stays without a comparison.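

In this assay, for the compounds shown here, compound 4 gives "not active" (no number reported), so no step from compound 3 to compound 4 can be read. No measured evidence bears on this result. The compounds shown leave open how far compound 2 and compound 4, both without a number, lie from compound 3.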